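This account rests on a few compounds, and the source may have more. Where it says the series, first, only, none or still open, it means among the compounds named here.

Measured in a functional assay on K562 cells (Homo sapiens) for cytotoxicity, read by CellTiter-Blue, with a stated time of 72 h; a higher number here means a weaker inhibitor, a lower number a stronger inhibitor:
- compound 1 `C/C=C(\C)[C@@H](O)[C@@H](C)[C@@H]1C/C=C(\C)C(=O)O[C@H](CC(C)C)C(=O)N[C@@H](C)C(=O)N(C)[C@H](Cc2ccccc2)C(=O)N(C)CC(=O)N[C@@H]([C@@H](C)CC)C(=O)N[C@H](C)C(=O)O1`: 0.012 nM
- compound 2 `C/C=C(\C)[C@H]1OC(=O)[C@@H](C)NC(=O)[C@H]([C@@H](C)CC)NC(=O)CN(C)C(=O)[C@@H](Cc2ccccc2)N(C)C(=O)[C@H](C)NC(=O)[C@@H](CC(C)C)OC(=O)/C(C)=C/C[C@H](OCSC)[C@@H]1C`: 0.0063 nM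
- compound 3 `C/C=C(\C)[C@H]1OC(=O)[C@@H](C)NC(=O)[C@H]([C@@H](C)CC)NC(=O)CN(C)C(=O)[C@@H](Cc2ccc(Cl)cc2)N(C)C(=O)[C@H](C)NC(=O)[C@@H](CC(C)C)OC(=O)/C(C)=C/C[C@H](O)[C@@H]1C`: 0.000011 nM

A lower number here means a stronger inhibitor, so compound 3 stands as the strongest of the three. Its value lies far beneath the other two, well beyond the scatter of repeated measurements. Compound 1 and compound 2 lie within the scatter of each other.

The next compound to be tested is compound 4 `C/C=C(\C)[C@H]1OC(=O)[C@@H](C)NC(=O)[C@H]([C@@H](C)CC)NC(=O)CN(C)C(=O)[C@@H](Cc2ccc(Cl)cc2)N(C)C(=O)[C@H](C)NC(=O)[C@@H](CC(C)C)OC(=O)/C(C)=C/C[C@H](OCSC)[C@@H]1C`, which is made from compound 3 by one change: (methylsulfanyl)methyl in place of hydrogen on an oxygen on a saturated carbon. A (methylsulfanyl)methyl group comes in place of hydrogen on an oxygen on a saturated carbon, so a hydroxy becomes a (methylsulfanyl)methoxy.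

Among the measured compounds shown here, no measured pair shows this change on its own, so any forecast is uncertain. For the measured compounds named here, the only guide is compound 2, which already carries the (methylsulfanyl)methoxy group and gives 0.0063 nM in this assay. A weaker result than that of compound 3 therefore seems likely, though probably not as weak as that of compound 2.

The expected change is a rise in the number beyond the scatter, a 27-fold higher number from compound 3 to compound 4 (1.44 log units; beyond the scatter). For compound 4 the estimated value is 0.0003 nM, with an expected range from 0.00002 nM to 0.005 nM.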

Compound 4, half-maximal inhibitory concentration: 7.1 nM
Beside the measured number, compound 4's estimate is 24000-fold (4.37 log units) below it; the measured number lies above the stated range.
By their numbers in this assay, from the lowest: compound 3; then compounds 2 and 1 (each within the scatter of the next); then compound 4.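

In this assay, the free hydroxy on this saturated carbon proves decisive once the aromatic chloro is present: putting (methylsulfanyl)methyl in place of its hydrogen gives a 650000-fold higher number from compound 3 to compound 4 (5.81 log units; beyond the scatter), a very large loss of strength. The earlier compounds shown here could not show this, since compound 2 carries the same (methylsulfanyl)methoxy group and still reaches 0.0063 nM, which made the group look harmless; with that group in place, chloro in place of hydrogen on an aromatic carbon gives a 1100-fold higher number from compound 2 to compound 4 (3.05 log units; beyond the scatter), so the chloro and the capped oxygen work badly together, and the effect of each change depends on the other. Nothing available here explains why these two changes combine so poorly.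

The compounds shown leave open whether the loss is specific to (methylsulfanyl)methyl or would also follow from a smaller group on that oxygen, such as a plain methyl ether or an acetyl ester. They also leave open whether a bromo or a fluoro in place of the chloro would meet the same penalty alongside the (methylsulfanyl)methoxy group.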